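Sulfonyl substituent variation in the aortic series

The source may hold more compounds than are shown below. What is called first, only, known or untested is meant among the compounds shown, and "the series" means these compounds.

For the measured compounds named here, compound 3 `CC1(C)Oc2ccc(S(=O)(=O)Nc3ccccc3)cc2[C@@H](/N=C(\NC#N)Nc2ccc(Cl)cc2)[C@@H]1O` gives 3300 nM in a functional assay (aorta) with Rattus norvegicus as the target (a higher number here means a weaker inhibitor, a lower number a stronger inhibitor), the second highest of the three numbers so far. Compound 1 `CC1(C)Oc2ccc(C#N)cc2[C@@H](/N=C(\NC#N)Nc2ccc(Cl)cc2)[C@@H]1O` gives 1800 nM, and the step of a 1.8-fold higher number from compound 1 to compound 3 (0.26 log units; within the scatter) is within the scatter, so the two are not ordered. Compound 2 `CC1(C)Oc2ccc(Cc3ccccc3)cc2[C@@H](/N=C(\NC#N)Nc2ccc(Cl)cc2)[C@@H]1O` gives 10000 nM, the highest number; the step of a 3.0-fold lower number from compound 2 to compound 3 (0.48 log units; beyond the scatter) is beyond the scatter, as is a 5.6-fold higher number from compound 1 to compound 2 (0.74 log units; beyond the scatter).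

Compound 4 `CC1(C)Oc2ccc(S(=O)(=O)N3CCOCC3)cc2[C@@H](/N=C(\NC#N)Nc2ccc(Cl)cc2)[C@@H]1O` carries morpholin-4-yl in place of anilino on a sulfonyl sulfur. Going by the values given here, no measured step touches the sulfonyl sulfur itself; the three steps all exchange the whole group on the aromatic carbon, and the largest of them is modest. The exchange on the sulfur, which keeps the sulfonyl in place, is therefore expected to produce a step no larger than those, most likely within the scatter, with no direction supported by the data.

Compound 4 is expected to give about 4000 nM, between 1500 nM and 12000 nM, a step of a 1.2-fold higher number from compound 3 to compound 4 (0.08 log units; within the scatter).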

Compound 4, half-maximal inhibitory concentration: 3100 nM
The estimate for compound 4 lay 1.3-fold (0.11 log units) above the measured number; the measured number falls inside the stated range.
By their numbers in this assay, from the lowest: compounds 1, 4 and 3 (each within the scatter of the next); then compound 2.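

In this assay, for the compounds shown here, this is the first change made on the sulfonyl sulfur itself, and a 1.1-fold lower number from compound 3 to compound 4 (0.03 log units; within the scatter) leaves the two compounds unresolved, even though anilino, with its aromatic ring and hydrogen-bond donor, gives way to morpholin-4-yl, with its non-aromatic ring and hydrogen-bond acceptor. The second sulfonyl compound also repeats how the first one reads against the other two groups: a 3.2-fold lower number from compound 2 to compound 4 (0.51 log units; beyond the scatter) lies beyond the scatter, like the step from compound 2 to compound 3, while a 1.7-fold higher number from compound 1 to compound 4 (0.24 log units; within the scatter) lies within it, like the step from compound 1 to compound 3. No evidence on the cause of this outcome is available.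

Still open, from the compounds shown here alone, is whether a smaller group on the sulfonyl sulfur, such as dimethylamino or methyl, would give a step beyond the scatter. Also open, going by these compounds, is how a carboxylic acid on the aromatic carbon would read against the nitrile of compound 1.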